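This account rests on a few compounds, and the source may have more. Where it says the series, first, only, none or still open, it means among the compounds named here.

In a functional assay on cells (Homo sapiens) for cytotoxicity, read by MTT assay, with a stated time of 24 h (on this read-out higher numbers stand for weaker inhibition and lower numbers for stronger inhibition), compound 2 (`CCCCCCCCCCCCCCNC(=O)[C@H](CO)/N=C/c1ccccc1OC`) gives 12500 nM, the lowest of the three numbers, while compound 1 (`CCCCCCCCCCCCCCNC(=O)[C@H](CO)/N=C/c1ccc(OC)cc1`) gives 28100 nM and compound 3 (`CCCCCCCCCCCCCCNC(=O)[C@H](CO)/N=C/c1cccc([N+](=O)[O-])c1`) gives 104000 nM. Compound 4 (`CCCCCCCCCCCCCCNC(=O)[C@H](CO)NCc1ccccc1OC`) differs from compound 2 on a saturated chain carbon bound to a carbonyl carbon and a saturated chain carbon, where (2-methoxybenzyl)amino enters: a group of 10 heavy atoms (8 carbon, 1 nitrogen, 1 oxygen; one six-membered aromatic ring of carbon only) in place of a group of 10 heavy atoms (8 carbon, 1 nitrogen, 1 oxygen; one six-membered aromatic ring of carbon only), on a saturated chain carbon bound to a carbonyl carbon and a saturated chain carbon. Among the compounds with values here, no measured step covers this change. The aryl swaps, a 2.2-fold lower number from compound 1 to compound 2 (0.35 log units; beyond the scatter) and an 8.3-fold higher number from compound 2 to compound 3 (0.92 log units; beyond the scatter), give only a rough scale. A step beyond the scatter is therefore not expected in this assay, and the data set no direction. The expected change is a 1.3-fold lower number from compound 2 to compound 4 (0.10 log units; within the scatter). For compound 4 the estimated value is 10000 nM, with an expected range of 4000 nM to 25000 nM.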

Compound 4, half-maximal inhibitory concentration: 100000 nM
Compound 4: the middle estimate sits 10-fold (1.00 log units) below what was measured; the whole stated range lies below it.
By their numbers in this assay, from the lowest: compound 2; then compound 1; then compounds 4 and 3 (each within the scatter of the next).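

In this assay, exchanging the group with the double bond outside the aromatic ring for (2-methoxybenzyl)amino gives an 8.0-fold higher number from compound 2 to compound 4 (0.90 log units; beyond the scatter), and the comparison with the other methoxy compound gives a 3.6-fold higher number from compound 1 to compound 4 (0.55 log units; beyond the scatter). The earlier compounds shown here varied only the aryl group, whereas this result shows that the link to that aryl group also moves the number. Nothing at hand accounts for this change.

On these data alone, only compound 4 carries the saturated link, so it remains open whether the rise holds for other aryl groups. Also open, as far as these compounds go, is whether a primary amine or an acetamide at this place would give a number nearer compound 2 or compound 4.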